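Swapping an imine for an acetoacetamide on a weak core

A few compounds are considered here, and "the series" means these few. Any claim that something is new, unique, unknown or untested is made for them only; others in the source may bear on it.

Of the compounds shown here, two sharing one core have been tested in a functional assay on MCF7 cells (Homo sapiens) for antiproliferative activity, read by sulforhodamine B assay, with a stated time of 48 h; a lower number here means a stronger inhibitor, a higher number a weaker inhibitor. Among the compounds with values here, compound 1 `CCO/C=N/C1=C(C#N)C(c2ccc(Cl)cc2)C2=C(CC(C)(C)CC2=O)N1c1ccc(S(N)(=O)=O)cc1` gives 97200 nM in this assay, and this is the only plain number among the two results. Compound 2 `CC1(C)CC(=O)C2=C(C1)N(c1ccc(S(N)(=O)=O)cc1)C(N)=C(C1=NCCN1)C2c1ccc(Cl)cc1` gives > 100000 nM in this assay, which is a limit of the assay and not a number. Within the data shown here, compound 1 therefore stands as the single measured value, while the other result sits at the limit of > 100000 nM in this assay, at which 1 of the 2 values shown sits.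

Compound 3 `CC(=O)CC(=O)NC1=C(C#N)C(c2ccc(Cl)cc2)C2=C(CC(C)(C)CC2=O)N1c1ccc(S(N)(=O)=O)cc1` has not yet been measured. It differs from compound 1 by a group of 7 heavy atoms (4 carbon, 1 nitrogen, 2 oxygen; no ring) in place of a group of 5 heavy atoms (3 carbon, 1 nitrogen, 1 oxygen; no ring), on a double-bonded ring carbon; in words, a group of 7 heavy atoms (4 carbon, 1 nitrogen, 2 oxygen; no ring) in place of a group of 5 heavy atoms (3 carbon, 1 nitrogen, 1 oxygen; no ring), on a double-bonded ring carbon.

Among the measured compounds shown here, no step between measured compounds that differ in one place is available, so nothing measured tells how this change acts. Compound 1 is already a weak inhibitor at 97200 nM, and the expected step from compound 1 to compound 3 is a 1.0-fold higher number from compound 1 to compound 3 (0.01 log units; within the scatter), which is not beyond the scatter. Compound 3 is estimated at 100000 nM, expected between 40000 nM and 250000 nM.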

Compound 3, half-maximal inhibitory concentration: > 100000 nM
Compound 3 ended at the assay's limit (the forecaster's own chance of this, stated with the estimate: 50%); the middle value sits exactly at the limit.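

As far as these compounds go, putting ((2-oxopropyl)carbonyl)amino on the double-bonded ring carbon, in place of the group carried there by compound 1, gives an at least 1.0-fold higher number from compound 1 to compound 3 (0.01 log units; that floor lies within the scatter); this is only a floor, so the true size of the step remains unknown. In this assay compound 3 gives > 100000 nM, which is a limit of the assay and not a number. The entering group brings a hydrogen-bond donor that the leaving group lacks, yet this change at this position does not produce a measurable number, and the limit now holds most of the results shown: the limit of > 100000 nM in this assay, at which 2 of the 3 values shown sit.

With a single plain value and two limits, the compounds shown cannot tell whether any group on this carbon can bring the number down, or how far above the limit compound 3 really lies. A smaller acetamide, a carboxylic acid or a morpholine ring at the same carbon would test whether this position can respond at all, though any such result would have to fall within the range of this assay to be compared.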